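This account rests on a few compounds, and the source may have more. Where it says the series, first, only, none or still open, it means among the compounds named here.

Measured so far:
compound 1, `O=C(/C=C/c1ccc(F)c(Cl)c1)c1ccc(B(O)O)cc1`: 22000 nM
compound 2, `O=C(O)COc1ccc(C(=O)/C=C/c2ccc(Cl)c(Cl)c2)cc1`: 15000 nM

In a functional assay on MCF-12A cells (Homo sapiens) for inhibition (a lower number here means a stronger inhibitor, a higher number a weaker inhibitor), compound 1 gives 22000 nM and compound 2 gives 15000 nM; the two numbers lie within the usual scatter of each other, so neither stands apart. Compound 3, `O=C(/C=C/c1ccc(Cl)c(Cl)c1)c1ccc(B(O)O)cc1`, has not yet been tested. The change from compound 2 is a group of 3 heavy atoms (1 boron, 2 oxygen; no ring) in place of a group of 5 heavy atoms (2 carbon, 3 oxygen; no ring), on an aromatic carbon. For the measured compounds named here, no measured pair shows this exchange directly. Still, compound 1 carries the same boron-bearing group on a differently substituted ring and sits close to compound 2, so the expected step is a 1.3-fold higher number from compound 2 to compound 3 (0.10 log units; within the scatter), not beyond the scatter. Compound 3 is estimated at 19000 nM, in a range of 8000 nM to 45000 nM.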

Compound 3, half-maximal inhibitory concentration: 11000 nM
Compound 3: the middle estimate sits 1.7-fold (0.24 log units) above what was measured; the measured number falls inside the stated range.
By their numbers in this assay, from the lowest: compounds 3, 2 and 1 (each within the scatter of the next).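

In this assay the exchange of carboxymethoxy for the boron-bearing group on this aromatic carbon can now be read directly: the result is a 1.4-fold lower number from compound 2 to compound 3 (0.13 log units; within the scatter), so the two groups cannot be told apart here. Chloro in place of fluoro on an aromatic carbon gives a 2.0-fold lower number from compound 1 to compound 3 (0.30 log units; within the scatter), so this change shows no clear effect either. Nothing available explains these results. On these data alone, whether an amine or a carboxylic acid on the same aromatic carbon would also stay within the scatter of these numbers remains open.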